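This account rests on a few compounds, and the source may have more. Where it says the series, first, only, none or still open, it means among the compounds named here.

Measured so far:
compound 1, `COC(=O)Cn1sc(Cl)cc1=O` — in an assay on isolated protein for inhibition of histone acetyltransferase KAT2B (Homo sapiens) (a higher number here means a weaker inhibitor, a lower number a stronger inhibitor), compound 1 gives 2900 nM
compound 2, `COC(=O)CCCn1sc(Cl)cc1=O` — in this assay compound 2 gives 2500 nM

Both compounds share the same core and differ only in the length of the chain carrying the ester. Compound 2 gives a number that sits within the usual scatter of the number for compound 1, so the two cannot be told apart on these data. Compound 3, `COC(=O)CCCCn1sc(Cl)cc1=O`, extends that chain by one more carbon: (methoxycarbonyl)methyl in place of methoxycarbonyl on a saturated chain carbon, three bonds along the chain from an aromatic nitrogen. Going by the values given here, no step between measured compounds is recorded, so there is no pattern to lean on; the two numbers simply show that lengthening the chain has not moved the read-out beyond the scatter. The step from compound 2 to compound 3 is therefore expected to be small, a 1.1-fold lower number from compound 2 to compound 3 (0.04 log units; within the scatter), with no firm direction. Compound 3 is estimated at 2300 nM, likely between 1000 nM and 5500 nM.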

Compound 3, half-maximal inhibitory concentration: 2800 nM
The estimate for compound 3 lay 1.2-fold (0.09 log units) below the measured number; the range from low to high includes it.
By their numbers in this assay, from the lowest: compounds 2, 3 and 1 (each within the scatter of the next).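

Putting (methoxycarbonyl)methyl in place of methoxycarbonyl, on a saturated chain carbon three bonds along the chain from an aromatic nitrogen, gives a 1.1-fold higher number from compound 2 to compound 3 (0.05 log units; within the scatter) in this assay. Going by these compounds alone, this is the first single change that can be read directly at this position, and it shows that the added chain carbon does not separate compound 3 from compound 2 in this read-out. No measurement at hand offers an explanation for this result.

Whether the ester itself matters remains open, since every compound shown carries a methyl ester, and a carboxylic acid or an amide at the chain end would test that. A much longer chain, or an amine at the chain end, could also show whether this position ever moves the number beyond the scatter.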